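Ethyl on the Phenol Oxygen: Expecting a Modest Gain

The source may report more compounds than this note shows. Statements on the series, on what has been measured and on what is new or still open speak of the compounds shown alone.

Of the compounds shown here, three sharing one core have been measured in a functional assay on aorta for antagonist activity at Alpha-1D adrenergic receptor (Rattus norvegicus); a higher number here means weaker binding, a lower number tighter binding. Compound 1 `COc1ccccc1N1CCN(CCCNc2ncccc2C(=O)N(C)C)CC1` carries a methoxy group on the phenyl ring and gives 20 nM. Compound 2 `CN(C)C(=O)c1cccnc1NCCCN1CCN(c2ccccc2C#N)CC1` carries a cyano group in that place, and compound 2 gives 10 nM; the step of a 2.0-fold lower number from compound 1 to compound 2 (0.30 log units; within the scatter) lies within the scatter. Compound 3 `CN(C)C(=O)c1cccnc1NCCCN1CCN(c2ccccc2O)CC1` carries a free hydroxy group, and compound 3 gives 63.1 nM, the highest number of the three: the step of a 3.2-fold higher number from compound 1 to compound 3 (0.50 log units; beyond the scatter) and the step of a 6.3-fold higher number from compound 2 to compound 3 (0.80 log units; beyond the scatter) both lie beyond the scatter, so compound 3 is the weakest of the measured set.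

Compound 4 `CCOc1ccccc1N1CCN(CCCNc2ncccc2C(=O)N(C)C)CC1` differs from compound 3 by ethyl in place of hydrogen on an oxygen on an aromatic ring. The step that bears most directly is a 3.2-fold higher number from compound 1 to compound 3 (0.50 log units; beyond the scatter), read in reverse: capping the hydroxy oxygen with a methyl gave a modestly lower number. Ethyl is larger than methyl, and no ethoxy compound has been measured, so how far that holds is unknown; the step of a 6.3-fold higher number from compound 2 to compound 3 (0.80 log units; beyond the scatter) only confirms that the free hydroxy gives the weakest result here. The expected step of a 2.5-fold lower number from compound 3 to compound 4 (0.40 log units; beyond the scatter) is therefore a modest lowering, of roughly the size seen with methyl. Compound 4 is estimated at 25 nM, with a range from 8 nM to 80 nM.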

Compound 4, dissociation constant: 7.94 nM
Estimate against measurement, compound 4: 3.1-fold (0.50 log units) above; measured number outside the range, below it.
By their numbers in this assay, from the lowest: compounds 4, 2 and 1 (each within the scatter of the next, the first and the last beyond it); then compound 3.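

Lengthening the cap on this oxygen from methyl to ethyl did not merely repeat the methyl result: ethyl gives the larger step (a 7.9-fold lower number from compound 3 to compound 4 (0.90 log units; beyond the scatter)), while methyl gave a smaller one, read in reverse from (a 3.2-fold higher number from compound 1 to compound 3 (0.50 log units; beyond the scatter)). The extra saturated carbon itself matters at this position, as the direct comparison of the ethoxy and methoxy compounds shows (a 2.5-fold lower number from compound 1 to compound 4 (0.40 log units; beyond the scatter)), so the size of the alkyl group on this oxygen changes the result and not only whether the oxygen is capped. The ethoxy group also reaches the level of the nitrile, with the two compounds not separable in this assay (a 1.3-fold lower number from compound 2 to compound 4 (0.10 log units; within the scatter)), so two quite different groups on this aromatic carbon give results that cannot be told apart.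

Going by these compounds, how a propyl group, an isopropyl group or a longer chain on the same oxygen would read remains open, so it is unknown whether the numbers keep falling past ethyl. The data shown offer no explanation for any of these differences.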